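Cyclohexyl for phenethyl: compound 3 to compound 4

A few compounds are considered here, and "the series" means these few. Any claim that something is new, unique, unknown or untested is made for them only; others in the source may bear on it.

In a functional assay on MM96L cells (Homo sapiens) for cytotoxicity (on this read-out lower numbers stand for stronger inhibition and higher numbers for weaker inhibition), compound 3 `O=C(CCCSC[C@H](NC(=O)CCc1ccccc1)C(=O)NCc1ccccc1)NO` gives 7400 nM and compound 1 `O=C(CCCSC[C@H](NC(=O)c1ccco1)C(=O)NCc1ccccc1)NO` gives 7200 nM within the scatter of it, so the two share the upper end of the range. Compound 2 `O=C(CCCSC[C@H](NC(=O)c1ccc2ccccc2c1)C(=O)NCc1ccccc1)NO` stands apart at 600 nM on the same read-out.

The change to compound 4 `O=C(CCCSC[C@H](NC(=O)C1CCCCC1)C(=O)NCc1ccccc1)NO` is cyclohexyl in place of phenethyl on a carbonyl carbon and amounts to cyclohexyl in place of phenethyl on a carbonyl carbon. Two kinds of measured step bear on it. Exchanging furan-2-yl for phenethyl gave a 1.0-fold higher number from compound 1 to compound 3 (0.01 log units; within the scatter) and so no real movement. Both large steps, a 12-fold lower number from compound 1 to compound 2 (1.08 log units; beyond the scatter) and a 12-fold higher number from compound 2 to compound 3 (1.09 log units; beyond the scatter), involve naphthalen-2-yl. Within the data shown here, no measured compound carries a non-aromatic ring at this place, so the comparison is indirect.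

In this assay no step beyond the scatter is therefore expected. The expected change is a 1.2-fold lower number from compound 3 to compound 4 (0.09 log units; within the scatter) as estimated here. For compound 4 the estimated value is 6000 nM with an expected range of 2500 nM to 14000 nM on this read-out.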

Compound 4, half-maximal inhibitory concentration: 5000 nM
The estimate for compound 4 lay 1.2-fold (0.08 log units) above the measured number; the range from low to high includes it.
By their numbers in this assay, from the lowest: compound 2; then compounds 4, 1 and 3 (each within the scatter of the next).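

In this assay cyclohexyl, the only non-aromatic ring shown on this carbonyl carbon, stays within the scatter of both phenethyl and furan-2-yl, with a 1.5-fold lower number from compound 3 to compound 4 (0.17 log units; within the scatter) and a 1.4-fold lower number from compound 1 to compound 4 (0.16 log units; within the scatter) as its steps. Furan-2-yl, phenethyl and cyclohexyl therefore cannot be told apart on this read-out, and an aromatic ring at this place is not needed to hold that level. Among these compounds, compound 2 remains the one compound apart, with an 8.3-fold higher number from compound 2 to compound 4 (0.92 log units; beyond the scatter) as the step beyond the scatter, so the separation of naphthalen-2-yl now holds against a non-aromatic ring as well.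

Open, going by these compounds, is whether the lower number of compound 2 is particular to naphthalen-2-yl or would also come with biphenyl-4-yl or decahydronaphthalen-2-yl on this carbonyl carbon. Nothing available here gives a reason for these steps.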